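From Ethylamino to Isopropylsulfanyl on the Carbonyl Carbon

The source may report more compounds than this note shows. Statements on the series, on what has been measured and on what is new or still open speak of the compounds shown alone.

Compound 1, `CCNC(=O)C1=C(C)NC(=O)NC1c1ccco1`: 1%
Compound 2, `CCNC(=O)C1=C(C)NC(=O)NC1c1ccsc1`: 1%

In an assay on membranes from HEK293 cells for displacement of a labelled ligand from adenosine receptor A2b (Homo sapiens), read by scintillation counting, with a stated time of 30 min, tested at 1 uM (a higher number here means more inhibition at the concentration tested (going by the name of the read-out), a lower number less inhibition), compound 1 gives 1%, and compound 2 gives 1%, so the step of no change at the digits printed from compound 1 to compound 2 (within the scatter) leaves the two level. Compound 2 therefore stands at the same low level as compound 1, with no inhibition to speak of in this assay.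

Compound 3, `CC1=C(C(=O)SC(C)C)C(c2ccsc2)NC(=O)N1`, has not yet been measured. It differs from compound 2 in one place: isopropylsulfanyl in place of ethylamino on a carbonyl carbon. Among the compounds with values here, no measured step touches the carbonyl carbon; the only measured step, no change at the digits printed from compound 1 to compound 2 (within the scatter), concerns the saturated ring carbon and was flat, so it shows only that the shared core has given no inhibition so far. Nothing measured argues for a step beyond the scatter in this assay in either direction. Compound 3 is therefore expected to give 2%, between 0% and 12%, which would mean an expected step of a number 1 percentage points higher from compound 2 to compound 3 (within the scatter).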

Compound 3, a percentage reported as inhibition, at one concentration (the size of the read-out at that concentration, not a potency): 14%
The estimate for compound 3 lay 12 percentage points below the measured number, and the stated range ends below it.
By their numbers in this assay, from the lowest: compounds 1 and 2 (each within the scatter of the next); then compound 3.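

In this assay, isopropylsulfanyl in place of ethylamino on a carbonyl carbon gives a number 13 percentage points higher from compound 2 to compound 3 (beyond the scatter), so this position responds to change in a way that the flat step on the saturated ring carbon did not show. The change removes the nitrogen with its hydrogen-bond donor and brings in sulfur with a branched chain, and this single step cannot separate those differences. Nothing available accounts for the rise.

The compounds shown leave open whether the sulfur or the isopropyl carries the step, a question that isopropylamino and ethylsulfanyl on the same carbonyl carbon would address. They also leave open how an isopropoxy group would compare there, and whether isopropylsulfanyl would give a similar step with furan-2-yl on the saturated ring carbon.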